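Swapping an aryl group on the sulfur of compound 1

The source may hold more compounds than are shown below. What is called first, only, known or untested is meant among the compounds shown, and "the series" means these compounds.

Compound 1 `CCCN(CCC)c1c([N+](=O)[O-])cc(Sc2ccc(OC)cc2)cc1[N+](=O)[O-]` was measured in a physicochemical assay for lipophilicity, measured as octanol-water partition (on this read-out lower numbers stand for lower lipophilicity and higher numbers for higher lipophilicity), where compound 1 gives 6.53. A second compound, compound 2 `COc1ccc(Sc2c([N+](=O)[O-])cc(C#N)cc2[N+](=O)[O-])cc1`, shares the bis-nitro ring and the sulfur-linked 4-methoxyphenyl group; in this assay compound 2 gives 3.56. Among the measured compounds shown here, of the two numbers measured so far, compound 1 has the higher one, and the gap to compound 2 is well beyond the usual scatter.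

Compound 3 `CCCN(CCC)c1c([N+](=O)[O-])cc(Sc2cc(C)c(Cl)cc2Cl)cc1[N+](=O)[O-]` has not yet been measured. It differs from compound 1 in one place: 2,4-dichloro-5-methylphenyl in place of 4-methoxyphenyl on a sulfur. For the measured compounds named here, no step between two measured compounds matches this change, so the expectation rests on the change itself. A rise beyond the scatter is expected, since the step from compound 1 to compound 3 is estimated at a number 1.87 log units higher from compound 1 to compound 3 (beyond the scatter). Compound 3 is therefore expected to give about 8.4 in this assay, within a range from 7.6 to 9.2.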

Compound 3, partition coefficient: 8.66
The estimate for compound 3 lay 0.26 log units below the measured number; measured number inside the range.
By their numbers in this assay, from the lowest: compound 2; then compound 1; then compound 3.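

On the read-out of this assay the group on the sulfur carries a large effect of its own: putting 2,4-dichloro-5-methylphenyl in place of 4-methoxyphenyl gives a clear rise (a number 2.13 log units higher from compound 1 to compound 3 (beyond the scatter)). Among the compounds shown here, the earlier pair could not show this, as compound 1 and compound 2 differ in more than one place, so this is the first step that isolates the group on the sulfur. Nothing at hand explains the size of this step.

From the compounds shown here alone, the step exchanges several features at once, with the methoxy oxygen leaving and two chlorine atoms and a methyl group entering, so the share of each stays unknown. Also open is how the number would move with a carboxylic acid or an amine on this aromatic ring, groups absent from the compounds shown.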